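Changing one aryl group: from compound 3 to compound 4

The compounds below may be only part of what the source reports. "The series", "measured", "known", "first", "only" and "open" are said of these compounds alone.

compound 1 `CC1(C)[C@H]2CC[C@]1(C)N(Cc1cn(-c3ccccc3Cl)nn1)C(=O)C2`: 270 nM
compound 2 `CC1(C)[C@H]2CC[C@]1(C)N(Cc1cn(-c3ccc(Br)cc3)nn1)C(=O)C2`: 200 nM
compound 3 `Cc1ccccc1-n1cc(CN2C(=O)C[C@@H]3CC[C@@]2(C)C3(C)C)nn1`: 250 nM

These three compounds were tested in a functional assay on PANC-1 cells (Homo sapiens) for inhibition, read by MTT assay, with a stated time of 24 h; on this read-out lower numbers stand for stronger inhibition and higher numbers for weaker inhibition. Compound 3, at 250 nM, cannot be told apart from the other two: a 1.1-fold lower number from compound 1 to compound 3 (0.03 log units; within the scatter) and a 1.3-fold higher number from compound 2 to compound 3 (0.10 log units; within the scatter). Compound 4 `COc1ccc(-n2cc(CN3C(=O)C[C@@H]4CC[C@@]3(C)C4(C)C)nn2)cc1` has 4-methoxyphenyl in place of 2-methylphenyl on an aromatic nitrogen. The measured steps that bear on this swap are those between the other groups at that place, including a 1.4-fold lower number from compound 1 to compound 2 (0.13 log units; within the scatter). All three stay small, so no step beyond the scatter is expected. However, no measured compound carries 4-methoxyphenyl, which leaves the range wide. The expected change is a 1.1-fold lower number from compound 3 to compound 4 (0.06 log units; within the scatter). For compound 4 the estimate is 220 nM, with an expected range of 100 nM to 480 nM.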

Compound 4, half-maximal inhibitory concentration: 330 nM
The estimate for compound 4 lay 1.5-fold (0.18 log units) below the measured number; the measured number falls inside the stated range.
By their numbers in this assay, from the lowest: compounds 2, 3, 1 and 4 (each within the scatter of the next).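

Within the data shown here, with 4-methoxyphenyl on the aromatic nitrogen, the first group here with a hydrogen-bond acceptor, the steps remain small: a 1.3-fold higher number from compound 3 to compound 4 (0.12 log units; within the scatter) and a 1.2-fold higher number from compound 1 to compound 4 (0.09 log units; within the scatter) and also a 1.7-fold higher number from compound 2 to compound 4 (0.22 log units; within the scatter) all stay within the usual variation. The four aryl groups at this place therefore cannot be told apart in this test, whether the substituent is chloro, bromo, methyl or methoxy. No supporting measurement is available to explain this result. From the compounds shown here alone, whether an amine or a carboxylic acid on the phenyl ring would move the number beyond the scatter remains open.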